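This account rests on a few compounds, and the source may have more. Where it says the series, first, only, none or still open, it means among the compounds named here.

Among the compounds with values here, in a functional assay on Raji cells (Homo sapiens) for inhibition, read by trypan blue exclusion, with a stated time of 72 h (a higher number here means a weaker inhibitor of growth, a lower number a stronger inhibitor of growth), compound 2 `Cn1c(=O)c(S(=O)(=O)c2ccc(F)cc2)cc2cnc(Nc3ccc4[nH]ccc4c3)nc21` gives 100 nM, the lower of the two numbers known so far, and compound 1 `Cn1c(=O)c(S(=O)(=O)c2ccc(OC(=O)CCCCC3SCC4NC(=O)NC43)cc2)cc2cnc(Nc3ccc4[nH]ccc4c3)nc21` gives 400 nM, a gap beyond the usual scatter. Compound 3 `Cn1c(=O)c(S(=O)(=O)c2ccc(O)cc2)cc2cnc(Nc3ccc4[nH]ccc4c3)nc21` remains unmeasured. It differs from compound 2 by hydroxy in place of fluoro on an aromatic carbon, with hydroxy in place of fluoro on an aromatic carbon, para to a large group. Within the data shown here, no measured step shows this change, so only a small rise in this assay is expected. The expected size is a 1.6-fold higher number from compound 2 to compound 3 (0.20 log units; within the scatter). For compound 3 the estimated value is 160 nM, with a range of 50 nM to 500 nM.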

Compound 3, concentration for 50% growth inhibition: 500 nM
For compound 3 the middle estimate is 3.1-fold (0.49 log units) below the measured one; the range from low to high includes it.
By their numbers in this assay, from the lowest: compound 2; then compounds 1 and 3 (each within the scatter of the next).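

On this aromatic carbon, para to a large group, the exchange of fluoro for hydroxy is not a neutral one: in this assay it gives a 5.0-fold higher number from compound 2 to compound 3 (0.70 log units; beyond the scatter). Compound 3 falls within the scatter of compound 1, so among the three compounds only compound 2, with its fluoro, stands apart. Nothing available accounts for this step. The compounds shown leave open how a methoxy group, an amine or a carboxylic acid on this carbon would compare with fluoro. They also leave open whether hydrogen there would stand closer to compound 2 or to compound 3.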